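Nitro in Place of Fluoro on the Anilino Ring

The source may hold more compounds than are shown below. What is called first, only, known or untested is meant among the compounds shown, and "the series" means these compounds.

For the measured compounds named here, compound 2 `C=CC(=O)Nc1cccc(NC(=O)CSc2nc(Nc3cccc(F)c3)c3ccccc3n2)c1` holds the lowest of the two numbers measured so far in a functional assay on NCI-H1975 cells (Homo sapiens) for inhibition, read by MTT assay, with a stated time of 72 h (a higher number here means a weaker inhibitor, a lower number a stronger inhibitor), where compound 2 gives 2030 nM. Going by the values given here, its only neighbour is compound 1 `C=CC(=O)Nc1cccc(NC(=O)CSc2nc(Nc3ccccc3)c3ccccc3n2)c1`, which in this assay gives 8120 nM; the two are separated by the step of a 4.0-fold lower number from compound 1 to compound 2 (0.60 log units; beyond the scatter). The next compound, compound 3 `C=CC(=O)Nc1cccc(NC(=O)CSc2nc(Nc3cccc([N+](=O)[O-])c3)c3ccccc3n2)c1`, has not yet been measured; it differs from compound 2 by nitro in place of fluoro on an aromatic carbon. Among the compounds with values here, only one measured step touches this part of the molecule, the replacement of hydrogen by fluoro, a 4.0-fold lower number from compound 1 to compound 2 (0.60 log units; beyond the scatter), which moved the number down by a modest amount. Within the data shown here, that step does not fix what a nitro group will do in place of fluoro, but since the one change seen at this carbon in compound 1 and compound 2 lowered the number, a small further step down, or none beyond the scatter, is expected for compound 3. The estimate for compound 3 in this assay is 1500 nM, within a range from 500 nM to 5000 nM, which corresponds to an expected step of a 1.4-fold lower number from compound 2 to compound 3 (0.13 log units; within the scatter).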

Compound 3, half-maximal inhibitory concentration: 22600 nM
For compound 3 the middle estimate is 15-fold (1.18 log units) below the measured one; the measured number lies above the stated range.
By their numbers in this assay, from the lowest: compound 2; then compound 1; then compound 3.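

In this assay, the change from 3-fluorophenyl to 3-nitrophenyl gives an 11-fold higher number from compound 2 to compound 3 (1.05 log units; beyond the scatter), which shows that a substituent at this aromatic carbon does not lower the number as a general rule: the outcome depends on which group is placed there. Against the unsubstituted parent, nitro in place of hydrogen gives a 2.8-fold higher number from compound 1 to compound 3 (0.44 log units; beyond the scatter), whereas fluoro in place of hydrogen gave a 4.0-fold lower number from compound 1 to compound 2 (0.60 log units; beyond the scatter), so the two groups move the number away from that of compound 1 in opposite directions at the same carbon. Nothing at hand bears on why the two groups part in this way.

With only hydrogen, fluoro and nitro at this carbon, the compounds shown do not tell whether the higher number is particular to nitro or would also appear with another group in the same place, such as a chlorine atom, a methoxy group, a nitrile or an amine. They also leave open whether fluoro and nitro would keep this same order on any other carbon of that ring, as every substituent shown here sits at this one position.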